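Series notes: adding a carboxy to the acid-bearing chain

The source may report more compounds than this note shows. Statements on the series, on what has been measured and on what is new or still open speak of the compounds shown alone.

Compound 1 `O=C(O)[C@@H]1CCCN1C(=O)CN(c1nc(Cl)nc2[nH]cnc12)C1CC1` gives 26% in a functional assay on the whole organism (Tail, strain ICR) with Mus musculus as the target, in the tail flick test, with a stated time of 90 min, at a dose of 25 umol/kg by the oral route (on this read-out higher numbers stand for a stronger effect at the one dose given and lower numbers for a weaker effect), and compound 2 `C[C@H](NC(=O)CN(c1nc(Cl)nc2[nH]cnc12)C1CC1)C(=O)O` gives 43.5%, so compound 2 stands highest of the two numbers, with compound 1 nearest. Within the data shown here, the single measured step is a number 17.5 percentage points higher from compound 1 to compound 2 (beyond the scatter). Compound 3 `O=C(O)C[C@H](NC(=O)CN(c1nc(Cl)nc2[nH]cnc12)C1CC1)C(=O)O` carries carboxy in place of hydrogen on a saturated chain carbon, two bonds along the chain from an amide-type nitrogen and a carbonyl carbon. Among the measured compounds shown here, that step swapped the whole amino acid part and does not bear directly on adding a carboxy, so no measured step speaks to this change. The step of a number 3.5 percentage points lower from compound 2 to compound 3 (within the scatter) is therefore expected to stay within the scatter. Compound 3 is estimated at 40%, range 20% to 60%.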

Compound 3, a percentage reported as activity, at one dose (the size of the read-out at that dose, not a potency): 25.1%
The estimate for compound 3 lay 14.9 percentage points above the measured number; measured number inside the range.
By their numbers in this assay, from the lowest: compounds 3 and 1 (each within the scatter of the next); then compound 2.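

Methyl to carboxymethyl on this saturated chain carbon gives a number 18.4 percentage points lower from compound 2 to compound 3 (beyond the scatter), so this position does not accept a carboxy without a change in the read-out. Among these compounds, this is the first step that isolates this carbon, as the earlier step replaced the whole amino acid part. Nothing available explains the change.

The compounds shown leave open whether the carboxylic acid itself or simply a larger group at this carbon goes with the lower number. A hydroxymethyl, a methyl ester or a primary amide at this carbon would help separate the two.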